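The compounds below may be only part of what the source reports. "The series", "measured", "known", "first", "only" and "open" are said of these compounds alone.

Measured compounds:
- compound 1 `O=C(NO)c1cc(F)c(Cn2nnc(-c3ccco3)n2)c(F)c1` — 3 nM
- compound 2 `CC(=O)Nc1ccc(C(=O)NO)cc1` — 270 nM
- compound 3 `CCN(CC)S(=O)(=O)c1cccc(-c2nnc(Sc3ccc(C(=O)NO)cc3)n2N)c1` — 9 nM

In an assay on Sf9 cells for inhibition of protein deacetylase HDAC6 (Homo sapiens), read by fluorescence (a lower number here means a stronger inhibitor, a higher number a weaker inhibitor), compound 1 gives 3 nM, the lowest of the three numbers. Compound 3 sits nearest to it with 9 nM, a gap that lies beyond the scatter, and compound 2 lies furthest away with 270 nM. For the measured compounds named here, all three share the hydroxamic acid on the benzene ring; the rest of each molecule differs widely, so no single step between measured compounds is available.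

Compound 4 `Nc1ccc(-c2nnn(Cc3c(F)cc(C(=O)NO)cc3F)n2)cc1` keeps the core of compound 1 and differs from it in one place: 4-aminophenyl in place of furan-2-yl on an aromatic carbon. Going by the values given here, no measured pair shows this kind of exchange, so the expectation rests only on the fact that the hydroxamic acid and the difluorobenzyl-tetrazole part of compound 1 are unchanged and that compound 1 already stands at 3 nM. The step from compound 1 to compound 4 in this assay is expected to be small, at most on the edge of the scatter, and if anything toward a slightly higher number: a 1.7-fold higher number from compound 1 to compound 4 (0.22 log units; within the scatter). Compound 4 is therefore estimated at 5 nM in this assay, with a plausible range from 2 nM to 15 nM.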

Compound 4, half-maximal inhibitory concentration: 3 nM
Estimate against measurement, compound 4: 1.7-fold (0.22 log units) above, and the stated range covers the measured number.
By their numbers in this assay, from the lowest: compounds 1 and 4 (each within the scatter of the next); then compound 3; then compound 2.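

In this assay, for the compounds shown here, the exchange of furan-2-yl for 4-aminophenyl on the aromatic carbon of the five-membered aromatic ring with 4 nitrogen gives no change at the digits printed from compound 1 to compound 4 (within the scatter) and so provides the first one-place step. Going by these compounds alone, at this position, a six-membered aromatic ring of carbon only, carrying a hydrogen-bond donor, can stand in place of a five-membered aromatic ring with 1 hetero atom without moving the number beyond the scatter, which the earlier compounds, with no step among them, could not show. No measured property of these compounds bears on why the number holds.

Going by these compounds, this single exchange does not separate the ring change from the amine, so a plain phenyl would be the informative comparison, and the reach of the position remains open for groups such as a carboxylic acid on the phenyl ring or a longer chain in place of the aromatic ring. On these data alone, how compound 1 and compound 4 compare on any other deacetylase also stays open.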